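Nitro in Place of Bromo on a Shared Ester Core

This account rests on a few compounds, and the source may have more. Where it says the series, first, only, none or still open, it means among the compounds named here.

Measured compounds:
compound 1, `O=C(O)C1=Cc2ccccc2OC1(OCc1cc(-c2ccc([N+](=O)[O-])cc2)no1)C(F)(F)F`: > 150000 nM
compound 2, `CCOC(=O)C1=Cc2ccccc2OC1(OCc1cc(-c2ccc(Br)cc2)no1)C(F)(F)F`: > 150000 nM

Of the compounds shown here, two have been measured in a functional assay on MCF7 cells (Homo sapiens) for inhibition, read by MTT assay, with a stated time of 24 h (on this read-out lower numbers stand for stronger inhibition and higher numbers for weaker inhibition), so far. Compound 1, `O=C(O)C1=Cc2ccccc2OC1(OCc1cc(-c2ccc([N+](=O)[O-])cc2)no1)C(F)(F)F`, gives only a limit in this assay, > 150000 nM. Compound 2, `CCOC(=O)C1=Cc2ccccc2OC1(OCc1cc(-c2ccc(Br)cc2)no1)C(F)(F)F`, likewise gives only a limit in this assay, > 150000 nM. No number stands for either of them, so compound 2 cannot be placed above or below compound 1; both sit at the same limit, as the limit of > 150000 nM in this assay, at which 2 of the 2 values shown sit, records.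

Compound 3, `CCOC(=O)C1=Cc2ccccc2OC1(OCc1cc(-c2ccc([N+](=O)[O-])cc2)no1)C(F)(F)F`, has not been measured. It differs from compound 2 by nitro in place of bromo on an aromatic carbon. Within the data shown here, no step between measured compounds is available, and both values on record are limits. With nothing pointing the other way, compound 3 is expected to sit at the same limit as compound 2, a step that the limit leaves unreadable from compound 2 to compound 3 that is not expected to exceed the scatter. The estimate for compound 3 in this assay is 200000 nM, within 100000 nM to 500000 nM.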

Compound 3, half-maximal inhibitory concentration: > 150000 nM
Compound 3 was reported as a limit; the forecaster's own chance of this, stated with the estimate: 85%; the middle value does not contradict the limit.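

In this assay compound 3 gives only a limit of > 150000 nM and no number. No step can be read from compound 2 or compound 1 to compound 3, as all three stand at one limit: the limit of > 150000 nM in this assay, at which 3 of the 3 values shown sit.

The compounds shown leave open whether nitro in place of bromo, or ethyl in place of hydrogen, makes any difference in this assay at concentrations beyond that limit.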